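This account rests on a few compounds, and the source may have more. Where it says the series, first, only, none or still open, it means among the compounds named here.

All three measured compounds share one core, and all were read in an ADME assay on Vero cells (Chlorocebus sabaeus) for cytotoxicity, with a stated time of 5 days; on this read-out higher numbers stand for weaker inhibition and lower numbers for stronger inhibition. In that assay compound 1 (`CN(C)c1nc(N)nc2c1ncn2[C@H]1C[C@H](N=[N+]=[N-])[C@@H](CO)O1`), which carries a dimethylamino group, gives > 100000 nM as a limit of the assay and not a number. Compound 2 (`CN(C)c1nc(Cl)nc2c1ncn2[C@H]1C[C@H](N=[N+]=[N-])[C@@H](CO)O1`) gives > 100000 nM and this too is a limit. Compound 3 (`COc1nc(OC)c2ncn([C@H]3C[C@H](N=[N+]=[N-])[C@@H](CO)O3)c2n1`) gives > 100000 nM as a further limit. Compound 1 therefore has no exact position and stands with the other two at the limit of > 100000 nM in this assay, at which 3 of the 3 values shown sit, in the data so far. Within the data shown here, the only measured step, a step that the two limits leave unreadable from compound 1 to compound 2 then, concerns another part of the molecule and offers no size to carry over.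

Compound 4 (`C=CCN(C)c1nc(N)nc2c1ncn2[C@H]1C[C@H](N=[N+]=[N-])[C@@H](CO)O1`) turns the dimethylamino group of compound 1 into allyl(methyl)amino, and the change is vinyl in place of hydrogen on a saturated chain carbon bound to a nitrogen on an aromatic ring in full. Among the measured compounds shown here, no measured step touches this place, so the data give no direct guide to its effect. With every measured compound at the limit of > 100000 nM in this assay, at which 3 of the 3 values shown sit, as the only reference, no step beyond the scatter is expected in this assay and no direction can be favoured. The expected outcome is a number no higher from compound 1 to compound 4 (the limit leaves the size open) on this estimate. For compound 4 the estimated value is 100000 nM with an expected range from 40000 nM to 200000 nM and a report as a limit is considered likely.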

Compound 4, half-maximal inhibitory concentration: 32000 nM
Compound 4: the middle estimate sits 3.1-fold (0.49 log units) above what was measured; the whole stated range lies above it.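

Among the compounds shown, this position is the only place where a change brings the read-out off the limit: the limit of > 100000 nM in this assay, at which 3 of the 4 values shown sit. In this assay, the change of dimethylamino to allyl(methyl)amino, with vinyl in place of hydrogen on a saturated chain carbon bound to a nitrogen on an aromatic ring, gives an at least 3.1-fold lower number from compound 1 to compound 4 (0.49 log units; beyond the scatter), so this position can alter the read-out where the earlier compounds gave no readable difference. Compound 1 gives > 100000 nM, which is a limit of the assay, so the step fixes a smallest size and leaves its true size open.

The compounds shown leave open whether the lower number goes with the double bond of the allyl group or with the longer chain alone, a question that a saturated propyl group in the same place would address. Also open, going by these compounds, is whether allyl(methyl)amino gives a similar step with chloro in place of amino, as in compound 2, whose own step from compound 1 cannot be read.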